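Pyridin-2-yl for pyridin-3-yl on a carbonyl carbon

The source may hold more compounds than are shown below. What is called first, only, known or untested is meant among the compounds shown, and "the series" means these compounds.

Of the compounds shown here, two with a shared core have numbers so far in a functional assay on MCF7 cells (Homo sapiens) for antiproliferative activity, with a stated time of 5 days; on this read-out lower numbers stand for stronger inhibition and higher numbers for weaker inhibition. Compound 1 (`CCCCc1ccc2[nH]c(-c3ccc(C(F)(F)F)cc3)c(/C=N/NC(=O)c3ccc(Cl)cc3)c2c1`) gives 1060 nM. Compound 2 (`CCCCc1ccc2[nH]c(-c3ccc(C(F)(F)F)cc3)c(/C=N/NC(=O)c3cccnc3)c2c1`) gives 260 nM, the lower of the two numbers. Putting pyridin-3-yl in place of 4-chlorophenyl on a carbonyl carbon accounts for a 4.1-fold lower number from compound 1 to compound 2 (0.61 log units; beyond the scatter), a modest step beyond the scatter.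

Compound 3 (`CCCCc1ccc2[nH]c(-c3ccc(C(F)(F)F)cc3)c(/C=N/NC(=O)c3ccccn3)c2c1`) changes that same place again, with pyridin-2-yl in place of pyridin-3-yl on a carbonyl carbon. For the measured compounds named here, only the one measured step bears on this change. It replaced a 4-chlorophenyl group, so it shows that the place responds but says nothing direct about exchanging one pyridinyl group for the other. Going by the values given here, no measured pair covers that exchange. A smaller change than the measured step is therefore expected, leaning towards a higher number, and it may well stay within the scatter. The expected move is a 1.5-fold higher number from compound 2 to compound 3 (0.16 log units; within the scatter). In this assay the estimated value for compound 3 is 380 nM, with an expected range from 130 nM to 1100 nM.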

Compound 3, half-maximal inhibitory concentration: 310 nM
Beside the measured number, compound 3's estimate is 1.2-fold (0.09 log units) above it; low and high end bracket the measured number.
By their numbers in this assay, from the lowest: compounds 2 and 3 (each within the scatter of the next); then compound 1.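

In this assay, the exchange of pyridin-3-yl for pyridin-2-yl on the carbonyl carbon gives a 1.2-fold higher number from compound 2 to compound 3 (0.08 log units; within the scatter), so this pair of groups, which have the same atoms joined differently, cannot be told apart by this read-out. The earlier compounds showed only that one pyridinyl group gave a lower number than 4-chlorophenyl; the second pyridinyl group now does the same, with a 3.4-fold lower number from compound 1 to compound 3 (0.53 log units; beyond the scatter), so among these three compounds both pyridinyl groups stand apart from 4-chlorophenyl, and none of the three goes against this. The compounds come with no evidence that could explain why the two pyridinyl groups read alike or why both differ from 4-chlorophenyl.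

The compounds shown leave open how a pyridin-4-yl group or an unsubstituted phenyl group on the same carbonyl carbon would compare, and so whether the difference from compound 1 goes with the pyridinyl groups themselves or with the loss of the chlorine. They also leave open whether a saturated ring such as piperidin-4-yl, or a small chain such as methyl, would be tolerated at this place in this assay.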